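Aryl in place of carbamoyl on the lactam ring carbon

A few compounds are considered here, and "the series" means these few. Any claim that something is new, unique, unknown or untested is made for them only; others in the source may bear on it.

Compound 1 `Cc1nn(-c2ncnc3nc[nH]c23)c2c1C(OC1CCCC1)CC(=O)N2`: 2 nM
Compound 2 `Cc1nn(-c2ncnc3nc[nH]c23)c2c1C(C(=O)N(C)c1ccccc1)CC(=O)N2`: 32 nM

In a functional assay on HEK293 cells for agonist activity at G-protein coupled receptor 39 (Homo sapiens), read by scintillation proximity assay and inositol phosphate accumulation, with a stated time of 75 min, in the presence of a further agent that is not named here (a lower number here means that less compound is needed, a higher number that more compound is needed for the effect), compound 2 gives 32 nM, the highest of the two numbers measured, with compound 1 the nearest at 2 nM. Compound 3 `Cc1nn(-c2ncnc3nc[nH]c23)c2c1C(c1ccc(F)cc1Cl)CC(=O)N2` differs from compound 2 in one place: 2-chloro-4-fluorophenyl in place of methyl(phenyl)carbamoyl on a saturated ring carbon. Within the data shown here, the only measured step, a 16-fold higher number from compound 1 to compound 2 (1.20 log units; beyond the scatter), bears on this position but involves neither group of the new change, so it sets only a rough scale. Compound 3 is expected to land between the two measured values, an estimated step of a 3.2-fold lower number from compound 2 to compound 3 (0.51 log units; beyond the scatter), giving an expected 10 nM with a range from 2 nM to 50 nM.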

Compound 3, half-maximal effective concentration: 9 nM
The estimate for compound 3 lay 1.1-fold (0.05 log units) above the measured number, and the stated range covers the measured number.
By their numbers in this assay, from the lowest: compound 1; then compound 3; then compound 2.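

In this assay the saturated ring carbon tolerates an aryl group without a carbonyl, as 2-chloro-4-fluorophenyl in place of methyl(phenyl)carbamoyl gives a 3.6-fold lower number from compound 2 to compound 3 (0.55 log units; beyond the scatter) on this position. The same aryl group does not match cyclopentyloxy, with a 4.5-fold higher number from compound 1 to compound 3 (0.65 log units; beyond the scatter) in the opposite direction, so compound 1 keeps the lowest number of the three. Nothing available here explains either step.

On these data alone, it remains open whether the chlorine or the fluorine contributes to the value of compound 3. As far as these compounds go, how an unsubstituted phenyl, an amine or a carboxylic acid would read on this carbon also remains open.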